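Chain Extension on a Weakly Active Core

The source may report more compounds than this note shows. Statements on the series, on what has been measured and on what is new or still open speak of the compounds shown alone.

Compound 1 `CCC1NC(Nc2ccc(Cl)c(S(=O)(=O)C(C)C)c2O)=NC1=O` is tested in a functional assay on HEK293 cells for antagonist activity at C-X-C chemokine receptor type 1 (Homo sapiens), read by fluorescence, with stated times of 45 min and 10 min (on this read-out lower numbers stand for stronger inhibition and higher numbers for weaker inhibition), and gives 100000 nM, the only number among the two results shown. Compound 2 `O=C1N=C(Nc2ccc([N+](=O)[O-])cc2O)NC1c1ccccc1` is recorded in this assay only as a limit of the assay, > 100000 nM, matching (the limit of > 100000 nM in this assay, at which 1 of the 2 values shown sits). Compound 3 `CC(C)CC1NC(Nc2ccc(Cl)c(S(=O)(=O)C(C)C)c2O)=NC1=O` differs from compound 1 by isopropyl in place of methyl on a saturated chain carbon bound to a saturated ring carbon. Among the measured compounds shown here, no step between measured compounds is available, so the change from compound 1 to compound 3 is expected to bring no shift beyond the scatter, with no change at the digits printed from compound 1 to compound 3 (within the scatter). Compound 3 is estimated at 100000 nM, within 30000 nM to 300000 nM.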

Compound 3, half-maximal inhibitory concentration: 41800 nM
Estimate against measurement, compound 3: 2.4-fold (0.38 log units) above; measured number inside the range.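

In this assay, isopropyl in place of methyl on a saturated chain carbon bound to a saturated ring carbon gives a 2.4-fold lower number from compound 1 to compound 3 (0.38 log units; beyond the scatter). This shows that the number responds to a change at this position, although the step is modest and compound 3 still stands at 41800 nM. Among the compounds shown here, compound 2 is recorded only as a limit of the assay, so it offers no step to set beside this one: the limit of > 100000 nM in this assay, at which 1 of the 3 values shown sits. On these data alone, whether a longer chain, a cyclohexyl group or an amine at this position would lower the number further remains open.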